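The source may report more compounds than this note shows. Statements on the series, on what has been measured and on what is new or still open speak of the compounds shown alone.

Series notes. Three measured compounds share one core bearing a benzyl group that carries a chloromethyl substituent; they differ only in where that substituent sits on the benzene ring. Compound 1 `ClCc1ccc(Cn2cnc3c(Cl)ncnc32)cc1`, compound 2 `ClCc1ccccc1Cn1cnc2c(Cl)ncnc21` and compound 3 `ClCc1cccc(Cn2cnc3c(Cl)ncnc32)c1` are the three arrangements. In a functional assay on DU-145 cells (Homo sapiens) for cytotoxicity, read by sulforhodamine B assay, with a stated time of 48 h (a higher number here means a weaker inhibitor of growth, a lower number a stronger inhibitor of growth), compound 1 gives 11800 nM. In this assay compound 2 gives 34700 nM. In this assay compound 3 gives 24000 nM. Compound 3 thus stands second highest of the three numbers: the number of compound 2 lies within the scatter of that of compound 3, so no order can be read between these two, whereas compound 1 gives a lower number than compound 3 by a margin beyond the scatter.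

Compound 4 `ClCc1cccc(Cn2cnc3c(Cl)nc(Cl)nc32)c1` is not yet measured. It keeps the skeleton of compound 3 and differs by chloro in place of hydrogen on an aromatic carbon. Going by the values given here, no pair of measured compounds differs in this way, so the size of the step rests on no measured precedent; the measured compounds vary only on the benzyl ring and say nothing about a change on the core. The step is expected to be small, if anything toward a somewhat lower number, and may well stay within the scatter. For compound 4 the estimate in this assay is 18000 nM, with a range from 6000 nM to 55000 nM. The step this estimate implies, a 1.3-fold lower number from compound 3 to compound 4 (0.12 log units; within the scatter), is expected to be modest.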

Compound 4, concentration for total growth inhibition: 2950 nM
Compound 4: the middle estimate sits 6.1-fold (0.79 log units) above what was measured; measured number outside the range, below it.
By their numbers in this assay, from the lowest: compound 4; then compound 1; then compounds 3 and 2 (each within the scatter of the next).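

In this assay, going by these compounds alone, chloro in place of hydrogen on an aromatic carbon between two ring nitrogen atoms gives an 8.1-fold lower number from compound 3 to compound 4 (0.91 log units; beyond the scatter), the first step that falls on the shared core rather than on the benzyl ring. This position therefore responds to substitution: one added chlorine, with no ring, no hydrogen-bond donor or acceptor and no net charge, shifts the number by a margin beyond the scatter, so the core cannot be treated as a silent part of these compounds. Nothing available accounts for the size or direction of this step.

Going by these compounds, the step rests on a single pair, so it remains open whether the lower number belongs to chloro specifically or would also follow from another group on the same carbon, such as an amine, a methoxy group or fluoro. Also open, on these data alone, is whether the same change on the core would give a step of similar size with the chloromethyl group placed as in compound 1 or compound 2.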